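A few compounds are considered here, and "the series" means these few. Any claim that something is new, unique, unknown or untested is made for them only; others in the source may bear on it.

Compound 2 `COc1cc2ncnc(Nc3cccc(Cl)c3F)c2cc1OCCCCC(=O)Nc1ccc(S(N)(=O)=O)cc1` gives 10500 nM in a functional assay on A549 cells (Homo sapiens) for antiproliferative activity, read by MTT assay, with a stated time of 72 h; a higher number here means a weaker inhibitor, a lower number a stronger inhibitor. Among the measured compounds shown here, the only other number in hand comes from compound 1 `COc1cc2ncnc(Nc3ccc(F)c(Br)c3)c2cc1OCCCCC(=O)Nc1ccc(S(N)(=O)=O)cc1`, which gives 16000 nM in this assay, and the step of a 1.5-fold lower number from compound 1 to compound 2 (0.18 log units; within the scatter) sits within the scatter, so the two compounds cannot be told apart on these numbers. Compound 3 `COc1cc2ncnc(Nc3ccc(C(F)(F)F)cc3)c2cc1OCCCCC(=O)Nc1ccc(S(N)(=O)=O)cc1` has not yet been measured. It differs from compound 2 by 4-(trifluoromethyl)phenyl in place of 3-chloro-2-fluorophenyl on a nitrogen on an aromatic ring. For the measured compounds named here, the one measured step that bears on this change, also an exchange of the aryl group on that nitrogen, is a 1.5-fold lower number from compound 1 to compound 2 (0.18 log units; within the scatter), which produced no shift beyond the scatter. On that basis no movement beyond the scatter is expected in this assay for compound 3, and the expected step is a 1.1-fold higher number from compound 2 to compound 3 (0.06 log units; within the scatter). Compound 3 is therefore estimated to give 12000 nM in this assay, with a range from 4000 nM to 36000 nM.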

Compound 3, half-maximal inhibitory concentration: 14800 nM
The estimate for compound 3 lay 1.2-fold (0.09 log units) below the measured number; the range from low to high includes it.
By their numbers in this assay, from the lowest: compounds 2, 3 and 1 (each within the scatter of the next).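

On the nitrogen on an aromatic ring, 4-(trifluoromethyl)phenyl in place of 3-chloro-2-fluorophenyl gives a 1.4-fold higher number from compound 2 to compound 3 (0.15 log units; within the scatter) in this assay, and in place of 3-bromo-4-fluorophenyl it gives a 1.1-fold lower number from compound 1 to compound 3 (0.03 log units; within the scatter). Among the compounds shown here, the earlier pair compared only two aryl groups that each carry two separate halogens, whereas this third group carries a single trifluoromethyl and no chlorine or bromine, and all three compounds still cannot be told apart. Nothing available explains why these exchanges leave the number within the scatter.

As far as these compounds go, it remains open whether an aryl group carrying an amine or a carboxylic acid, or a plain phenyl, on this nitrogen would move the number beyond the scatter. The compounds shown also leave open what a longer chain at the other end of the core would do.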